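Methyl in Place of Methoxy on a Non-Cytotoxic Core

The source may report more compounds than this note shows. Statements on the series, on what has been measured and on what is new or still open speak of the compounds shown alone.

Compound 1 `COc1ccc2[nH]c(=O)c(-c3nc4cc(F)ccc4[nH]3)cc2c1`: > 100000 nM
Compound 2 `O=c1[nH]c2ccccc2cc1-c1nc2cc([N+](=O)[O-])ccc2[nH]1`: > 100000 nM
Compound 3 `COc1ccc2[nH]c(=O)c(-c3nc4cc(Cl)ccc4[nH]3)cc2c1`: > 100000 nM

In an ADME assay on L02 cells (Homo sapiens) for cytotoxicity, read by MTT assay, with a stated time of 48 h (on this read-out lower numbers stand for stronger inhibition and higher numbers for weaker inhibition), compound 3 gives only a limit, > 100000 nM, not a number. Compound 1 likewise sits at a limit in this assay. Compound 2 too sits at a limit. Among the compounds with values here, the one measured step, a step that the two limits leave unreadable from compound 1 to compound 3, is therefore unreadable, and the whole picture rests on (the limit of > 100000 nM in this assay, at which 3 of the 3 values shown sit). Compound 4 `Cc1ccc2[nH]c(=O)c(-c3nc4cc(Cl)ccc4[nH]3)cc2c1` differs from compound 3 by methyl in place of methoxy on an aromatic carbon. Within the data shown here, no measured step bears on this change, and with every value at the limit no step beyond the scatter can be expected in this assay. Compound 4 is therefore estimated at 150000 nM, with a range from 50000 nM to 500000 nM. The expected step is a step that the limit leaves unreadable from compound 3 to compound 4, most likely again reported as a limit.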

Compound 4, half-maximal inhibitory concentration: > 100000 nM
Compound 4 gave a limit, no number; the forecaster's own chance of this, stated with the estimate: 85%; the middle value is on the limit's open side.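

Compound 3 and compound 4 each give only a limit, so no step can be read between them: the limit of > 100000 nM in this assay, at which 4 of the 4 values shown sit.

The compounds shown leave open what methyl in place of methoxy does where a real number can be read.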